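The source may hold more compounds than are shown below. What is called first, only, known or untested is meant among the compounds shown, and "the series" means these compounds.

Three compounds share one core and differ only in the group attached to the carbonyl carbon of the amide. Compound 1 `CCCC(=O)Nc1c(C(O)(C(F)(F)F)C(F)(F)F)ccc2ccccc12` carries a propyl there and in an assay on LtK cells with ATP-sensitive inward rectifier potassium channel 11 (Homo sapiens) as the target (a higher number here means that more compound is needed for the effect, a lower number that less compound is needed), compound 1 gives 131 nM. Compound 2 `C/C=C/C(=O)Nc1c(C(O)(C(F)(F)F)C(F)(F)F)ccc2ccccc12` carries a prop-1-en-1-yl, and in this assay compound 2 gives 72 nM. Compound 3 `O=C(CC1CCCC1)Nc1c(C(O)(C(F)(F)F)C(F)(F)F)ccc2ccccc12` carries a cyclopentylmethyl, and in this assay compound 3 gives 81 nM. Compound 2 stands at the lowest of the three numbers, yet the steps of a 1.8-fold lower number from compound 1 to compound 2 (0.26 log units; within the scatter) and a 1.1-fold higher number from compound 2 to compound 3 (0.05 log units; within the scatter) both stay within the scatter, so the three compounds cannot be told apart on these numbers.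

Compound 4 `O=C(Nc1c(C(O)(C(F)(F)F)C(F)(F)F)ccc2ccccc12)c1ccccc1Cl` changes the same carbonyl carbon once more: 2-chlorophenyl in place of prop-1-en-1-yl on a carbonyl carbon. Both measured changes at this position, a 1.8-fold lower number from compound 1 to compound 2 (0.26 log units; within the scatter) and a 1.1-fold higher number from compound 2 to compound 3 (0.05 log units; within the scatter), were small, and a 1.6-fold lower number from compound 1 to compound 3 (0.21 log units; within the scatter) was small as well. For the measured compounds named here, no measured compound carries an aromatic ring at this position, so the step to compound 4 is expected to be no larger than the scatter, with the estimate a 1.3-fold higher number from compound 2 to compound 4 (0.10 log units; within the scatter). Compound 4 is therefore estimated at 90 nM, with a range from 30 nM to 270 nM.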

Compound 4, half-maximal effective concentration: 2040 nM
Beside the measured number, compound 4's estimate is 23-fold (1.36 log units) below it; measured number outside the range, above it.
By their numbers in this assay, from the lowest: compounds 2, 3 and 1 (each within the scatter of the next); then compound 4.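

This position is less forgiving than the three earlier compounds suggested: in this assay, 2-chlorophenyl on the carbonyl carbon gives a 28-fold higher number from compound 2 to compound 4 (1.45 log units; beyond the scatter), and the same group gives a 25-fold higher number from compound 3 to compound 4 (1.40 log units; beyond the scatter) and a 16-fold higher number from compound 1 to compound 4 (1.19 log units; beyond the scatter) as well. All three steps lie beyond the scatter, whereas propyl, prop-1-en-1-yl and cyclopentylmethyl could not be told apart, so the group here can strongly shift the number, and this shift appears with the only aromatic ring shown at this position. No available evidence bears on why the number rises so far.

As far as these compounds go, whether the ring or the chlorine goes with the higher number stays open, and a plain phenyl would separate the two. From the compounds shown here alone, how a cyclohexyl or a longer chain would read at this carbonyl carbon is also open.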